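From cyano to methylsulfonyl on a limit-bound compound

The source may hold more compounds than are shown below. What is called first, only, known or untested is meant among the compounds shown, and "the series" means these compounds.

In an ADME assay on BJ cells (Homo sapiens) for cytotoxicity, with a stated time of 72 h (a lower number here means that less compound is needed, a higher number that more compound is needed for the effect), compound 1 `CCCc1ccc(-c2nc3c(c(C)nn3-c3ccccc3)c(-c3ccccc3O)c2C#N)cc1` reads 22500 nM as a measured number. Compound 2 `Cc1nn(-c2ccccc2)c2nc(-c3ccc(C#N)cc3)c(C#N)c(-c3ccccc3O)c12` stands at > 20000 nM and that is only a limit. Compound 3 `Cc1nn(-c2ccccc2)c2nc(-c3ccc(S(C)(=O)=O)cc3)c(C#N)c(-c3ccccc3O)c12` carries methylsulfonyl in place of cyano on an aromatic carbon and has yet to be measured. With only a step that the limit leaves unreadable from compound 1 to compound 2 on record and no size to carry over, no step beyond the scatter is expected in this assay for this change. The estimate is a step that the limit leaves unreadable from compound 2 to compound 3 on this reasoning. Compound 3 is expected at 25000 nM with an estimated range from 10000 nM to 60000 nM around it.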

Compound 3, half-maximal effective concentration: > 20000 nM
Compound 3: no number, only a limit; the forecaster's own chance of this, stated with the estimate: 60%; the middle value lies beyond the limit too.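

In this assay no new step can be read among compound 1, compound 2 and compound 3, because compound 2 and compound 3 give only a limit: the limit of > 20000 nM in this assay, at which 2 of the 3 values shown sit.

From the compounds shown here alone, whether compound 2 and compound 3 differ from each other or from compound 1 stays open.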